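Compound 3 to compound 4: 4-nitrophenyl to 2-nitrophenyl

This account rests on a few compounds, and the source may have more. Where it says the series, first, only, none or still open, it means among the compounds named here.

In a functional assay on A549 cells (Homo sapiens) for cytotoxicity, read by MTT assay, with a stated time of 24 h (on this read-out higher numbers stand for weaker inhibition and lower numbers for stronger inhibition), compound 1 (`COc1cc(/C=C(\C#N)C(=O)N/N=C(\C)c2c(O)c3ccc(O)cc3oc2=O)ccc1O`) gives 12600 nM, compound 2 (`COc1ccc(/C=C(\C#N)C(=O)N/N=C(\C)c2c(O)c3ccc(O)cc3oc2=O)cc1OC`) gives 14300 nM and compound 3 (`C/C(=N\NC(=O)/C(C#N)=C/c1ccc([N+](=O)[O-])cc1)c1c(O)c2ccc(O)cc2oc1=O`) gives 9640 nM. Compound 3 therefore stands within the scatter of both other compounds, and the three are not separated. Compound 4 (`C/C(=N\NC(=O)/C(C#N)=C/c1ccccc1[N+](=O)[O-])c1c(O)c2ccc(O)cc2oc1=O`) carries 2-nitrophenyl in place of 4-nitrophenyl on a double-bonded chain carbon bound to a double-bonded chain carbon. Among the measured compounds shown here, no measured compound carries 2-nitrophenyl, so the evidence is indirect. The closest steps exchange the whole group at this same place: a 1.3-fold lower number from compound 1 to compound 3 (0.12 log units; within the scatter) and a 1.5-fold lower number from compound 2 to compound 3 (0.17 log units; within the scatter). The remaining step, a methyl in place of hydrogen on an oxygen, gives a 1.1-fold higher number from compound 1 to compound 2 (0.05 log units; within the scatter). All three stay within the scatter, although they cover only these three compounds. No step beyond the scatter is expected, and the estimated step is a 1.1-fold higher number from compound 3 to compound 4 (0.04 log units; within the scatter). For compound 4 the estimated value is 10500 nM, with an expected range of 5500 nM to 20000 nM.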

Compound 4, half-maximal inhibitory concentration: 11400 nM
Estimate against measurement, compound 4: 1.1-fold (0.04 log units) below, and the stated range covers the measured number.
By their numbers in this assay, from the lowest: compounds 3, 4, 1 and 2 (each within the scatter of the next).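

Among the compounds shown here, this is the first change at this place that keeps the atoms of the group and only joins them differently: in this assay, 2-nitrophenyl in place of 4-nitrophenyl gives a 1.2-fold higher number from compound 3 to compound 4 (0.07 log units; within the scatter). The exchanges against the other groups also stay inside the noise, with a 1.3-fold lower number from compound 2 to compound 4 (0.10 log units; within the scatter) and a 1.1-fold lower number from compound 1 to compound 4 (0.04 log units; within the scatter), so 2-nitrophenyl is not separated from 4-nitrophenyl, 3,4-dimethoxyphenyl or 4-hydroxy-3-methoxyphenyl, and all four compounds remain one group on this read-out. Nothing available here offers an explanation for this flat response.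

Still open, from the compounds shown here alone, is whether an amine or a carboxylic acid on the phenyl ring at this place would give a step beyond the scatter. Also open, going by these compounds, is whether replacing the methyl on the chain carbon bearing the shared core with a longer chain would separate these compounds in this assay.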